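Thiophene for fluorophenyl on the hydrazone carbon

A few compounds are considered here, and "the series" means these few. Any claim that something is new, unique, unknown or untested is made for them only; others in the source may bear on it.

Working notes on a small series built on one shared core. Compound 1 `CCCSc1nc(N/N=C/c2ccccc2F)c2nnn(Cc3ccccc3)c2n1` carries a 2-fluorophenyl on a carbon with a double bond to nitrogen. In a functional assay on MCF7 cells (Homo sapiens) for antiproliferative activity, read by MTT assay, with a stated time of 72 h (a higher number here means a weaker inhibitor, a lower number a stronger inhibitor), compound 1 gives only a limit, > 64000 nM, so no number is known for it. That reading sits at the limit of > 64000 nM in this assay, at which 1 of the 2 values shown sits. Among the measured compounds shown here, compound 2 `CCCSc1nc(N/N=C(\C)c2ccccc2O)c2nnn(Cc3ccco3)c2n1` differs from compound 1 in several places at once; in this assay compound 2 gives 29000 nM, and with no single-point step between the two, their values show no more than that. Compound 3 `CCCSc1nc(N/N=C/c2cccs2)c2nnn(Cc3ccccc3)c2n1` differs from compound 1 by thiophen-2-yl in place of 2-fluorophenyl on a carbon with a double bond to nitrogen. For the measured compounds named here, no measured pair covers this change. The step from compound 1 to compound 3 is expected to stay within the scatter, an at least 1.0-fold lower number from compound 1 to compound 3 (0.02 log units; that floor lies within the scatter), and a limit reading is again considered likely. For compound 3 the estimate in this assay is 60000 nM, with a range from 20000 nM to 200000 nM.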

Compound 3, half-maximal inhibitory concentration: > 64000 nM
Compound 3: a limit, no number (the forecaster's own chance of this, stated with the estimate: 60%); at least 1.0-fold (0.02 log units) between middle value and limit.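

In this assay compound 3 gives > 64000 nM, a limit and not a number. Among the compounds shown here, compound 1 also stands at a limit, so no step between compound 1 and compound 3 can be read. The compounds shown leave open whether thiophen-2-yl in place of 2-fluorophenyl changes the antiproliferative reading at all.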